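Selenobenzyl for methylsulfanyl on the amidine carbon

This account rests on a few compounds, and the source may have more. Where it says the series, first, only, none or still open, it means among the compounds named here.

Measured so far, in a functional assay on HepG2 cells (Homo sapiens) for cytotoxicity, read by MTT assay, with a stated time of 72 h; a lower number here means a stronger inhibitor of growth, a higher number a weaker inhibitor of growth:
compound 1, `CS/C(=N\C(=O)c1cc2ccccc2s1)NC(=O)c1cc2ccccc2s1`, gives 53000 nM;
compound 2, `O=C(/N=C(/NC(=O)c1cccs1)[Se]Cc1ccccc1)c1cccs1`, gives 58100 nM;
compound 3, `CS/C(=N\C(=O)c1cccs1)NC(=O)c1cccs1`, gives only a limit of the assay, > 100000 nM.

Compound 1 and compound 2 sit within the scatter of each other in this assay, so no order between them is claimed. Compound 3 stands at a limit, and no number is known for it.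

Within the data shown here, the one change that is measured is a group of 8 heavy atoms (7 carbon, 1 selenium; one six-membered aromatic ring of carbon only) in place of a group of 2 heavy atoms (1 carbon, 1 sulfur; no ring), on a carbon with a double bond to nitrogen. It produced an at least 1.7-fold lower number from compound 3 to compound 2 (0.23 log units; that floor lies within the scatter). That step is only a floor because of the limit of > 100000 nM in this assay, at which 1 of the 3 values shown sits.

Compound 4, `O=C(/N=C(/NC(=O)c1cc2ccccc2s1)[Se]Cc1ccccc1)c1cc2ccccc2s1`, has not yet been measured in this assay. It carries the same kind of change on the core of compound 1: a group of 8 heavy atoms (7 carbon, 1 selenium; one six-membered aromatic ring of carbon only) in place of a group of 2 heavy atoms (1 carbon, 1 sulfur; no ring), on a carbon with a double bond to nitrogen. The two cores themselves, that of compound 1 and that of compound 3, differ in a way that is not broken down here.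

The expectation for compound 4 rests on one pair only. If the change behaves on the core of compound 1 as it did on the core of compound 3, compound 4 is expected to give a lower number than compound 1, roughly by a 1.8-fold lower number from compound 1 to compound 4 (0.25 log units; within the scatter), taking the floor of an at least 1.7-fold lower number from compound 3 to compound 2 (0.23 log units; that floor lies within the scatter) as a guide to its size. On that basis the estimate for compound 4 in this assay is 30000 nM, with a range from 12000 nM to 70000 nM, the width reflecting that a single floored step is the whole ground for it.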

Compound 4, concentration for total growth inhibition: 49000 nM
For compound 4 the middle estimate is 1.6-fold (0.21 log units) below the measured one; the measured number falls inside the stated range.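

In this assay, the selenobenzyl group in place of methylsulfanyl, on a carbon with a double bond to nitrogen, gives a 1.1-fold lower number from compound 1 to compound 4 (0.03 log units; within the scatter), so on the core of compound 1 the change leaves nothing that can be told from the scatter. Set beside the step on the core of compound 3, the comparison reads as follows: the same change on two cores in this assay, an at least 1.7-fold lower number (0.23 log units; that floor lies within the scatter) from compound 3 to compound 2 and a 1.1-fold lower number (0.03 log units; within the scatter) from compound 1 to compound 4; the limit leaves it open whether they differ The pair therefore does not show that the change carries from one core to the other, nor that it fails to carry, because the step on the core of compound 3 is only a floor: the limit of > 100000 nM in this assay, at which 1 of the 4 values shown sits.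

Still open, from the compounds shown here alone, is whether selenium or the benzyl ring accounts for any part of the step, a question that a benzyl group on sulfur or a methyl group on selenium, set on each of the two cores, would bear on. Also open, going by these compounds, is how an amine on the same carbon would compare with methylsulfanyl and the selenobenzyl group on either core, and whether any step on the core of compound 3 has a size that can be stated as a number rather than as a floor.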